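The compounds below may be only part of what the source reports. "The series", "measured", "known", "first", "only" and "open" are said of these compounds alone.

In a functional assay on A549 cells (Homo sapiens) for inhibition, read by sulforhodamine B assay (a lower number here means a stronger inhibitor of growth, a higher number a weaker inhibitor of growth), compound 1 `c1ccc(-c2ccc(-c3ccc(-c4nc5ccccc5[nH]4)cc3)cc2)cc1` gives 41200 nM and compound 2 `FC(F)(F)c1ccc(-c2ccc(-c3ccc(-c4nc5ccccc5[nH]4)cc3)cc2)cc1` gives 36600 nM, while compound 3 `FC(F)(F)Oc1ccc(-c2ccc(-c3ccc(-c4nc5ccccc5[nH]4)cc3)cc2)cc1` gives 38000 nM and so sits level with both. Placing trifluoromethyl (a 1.1-fold lower number from compound 1 to compound 2 (0.05 log units; within the scatter)) or trifluoromethoxy (a 1.1-fold lower number from compound 1 to compound 3 (0.04 log units; within the scatter)) on compound 1 stayed within the scatter, as did exchanging one group for the other (a 1.0-fold higher number from compound 2 to compound 3 (0.02 log units; within the scatter)). Compound 4 `Oc1ccc(-c2ccc(-c3ccc(-c4nc5ccccc5[nH]4)cc3)cc2)cc1` has hydrogen in place of trifluoromethyl on an oxygen on an aromatic ring, so trifluoromethoxy becomes hydroxy (hydrogen in place of trifluoromethyl on an oxygen on an aromatic ring). Among the measured compounds shown here, no measured compound carries hydroxy, so these steps are only indirect guides. Since none left the scatter, the expected step (a 1.2-fold lower number from compound 3 to compound 4 (0.06 log units; within the scatter)) is likewise no larger than the scatter. For compound 4 the estimated value is 33000 nM (expected range 12000 nM to 60000 nM).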

Compound 4, concentration for 50% growth inhibition: 33100 nM
Compound 4: the middle estimate sits 1.0-fold (0.00 log units) below what was measured, within the range that was stated.
By their numbers in this assay, from the lowest: compounds 4, 2, 3 and 1 (each within the scatter of the next).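

Hydroxy, which puts a hydrogen on the oxygen in place of trifluoromethyl, also stays within the scatter: a 1.1-fold lower number from compound 3 to compound 4 (0.06 log units; within the scatter), a 1.1-fold lower number from compound 2 to compound 4 (0.04 log units; within the scatter) and a 1.2-fold lower number from compound 1 to compound 4 (0.10 log units; within the scatter). Four different groups at this position, hydrogen, trifluoromethyl, trifluoromethoxy and hydroxy, therefore cannot be told apart by this growth read-out. No other measurement is available to explain this flat result. Going by these compounds, whether an amine, a carboxylic acid or a longer chain at this position would leave the scatter remains open. Also open, on these data alone, is whether a change elsewhere on the shared core would move the number.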